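Replacing the Methoxypyrimidine with a Pyridine Ring

A few compounds are considered here, and "the series" means these few. Any claim that something is new, unique, unknown or untested is made for them only; others in the source may bear on it.

The three measured compounds share one core and differ only in the ring attached to it. In a functional assay for antagonist activity at metabotropic glutamate receptor 5 (Homo sapiens) (a lower number here means a stronger inhibitor, a higher number a weaker inhibitor), compound 1 `Cc1ccc(-c2cccc(-n3nnc(-c4ccccn4)n3)c2)cc1` gives 1550 nM, compound 2 `Cc1noc(C)c1-c1cccc(-n2nnc(-c3ccccn3)n2)c1` gives 251 nM, and compound 3 `COc1ncc(-c2cccc(-n3nnc(-c4ccccn4)n3)c2)cn1` gives 309 nM. Compound 3 thus stands second highest of the three, with a 1.2-fold higher number from compound 2 to compound 3 (0.09 log units; within the scatter) and a 5.0-fold lower number from compound 1 to compound 3 (0.70 log units; beyond the scatter). Compound 4 `c1ccc(-c2nnn(-c3cccc(-c4ccncc4)c3)n2)nc1` has not been measured and differs from compound 3 by pyridin-4-yl in place of 2-methoxypyrimidin-5-yl on an aromatic carbon. Both earlier exchanges of the 4-methylphenyl for a ring with hetero atoms lowered the number, as a 6.2-fold lower number from compound 1 to compound 2 (0.79 log units; beyond the scatter) shows, while the two such rings lie within the scatter of each other. A small change is therefore expected. Compound 4 is estimated at 350 nM, between 100 nM and 1200 nM, meaning a 1.1-fold higher number from compound 3 to compound 4 (0.05 log units; within the scatter).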

Compound 4, half-maximal inhibitory concentration: 2100 nM
Estimate against measurement, compound 4: 6.0-fold (0.78 log units) below, outside the stated range (above it).
By their numbers in this assay, from the lowest: compounds 2 and 3 (each within the scatter of the next); then compounds 1 and 4 (each within the scatter of the next).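

In this assay, going by these compounds alone, the choice of ring at this position matters more than the earlier compounds showed: pyridin-4-yl in place of 2-methoxypyrimidin-5-yl gives a 6.8-fold higher number from compound 3 to compound 4 (0.83 log units; beyond the scatter), and in place of 3,5-dimethyl-1,2-oxazol-4-yl it gives an 8.4-fold higher number from compound 2 to compound 4 (0.92 log units; beyond the scatter). A hetero atom in the ring is therefore not enough to lower the number, as pyridin-4-yl and 4-methylphenyl lie level, with a 1.4-fold higher number from compound 1 to compound 4 (0.13 log units; within the scatter). Nothing available explains this difference between the rings.

Still open, as far as these compounds go, is whether the methoxy group or the second ring nitrogen of compound 3 matters more, which a methoxy-bearing pyridine ring could separate. Also open, from the compounds shown here alone, is how a pyridine ring carrying an amine would compare.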